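The source may report more compounds than this note shows. Statements on the series, on what has been measured and on what is new or still open speak of the compounds shown alone.

Measured in a functional assay on ZR-75-1 cells (Homo sapiens) for inhibition, read by sulforhodamine B assay; a lower number here means a stronger inhibitor of growth, a higher number a weaker inhibitor of growth:
- compound 1 `Cc1ccc2[nH]c(-c3ccc(-c4ccc(-c5cccc(Cl)c5)cc4)cc3)nc2c1`: 3450 nM
- compound 2 `Fc1ccc(-c2ccc(-c3ccc(-c4nc5ccccc5[nH]4)cc3)cc2)cc1`: 100000 nM
- compound 3 `Oc1ccc(-c2ccc(-c3ccc(-c4nc5ccccc5[nH]4)cc3)cc2)cc1`: 100000 nM

Compound 3 stands level with compound 2, and these two share the highest number of the three, while compound 1 lies well below them. Compound 4 `Clc1cccc(-c2ccc(-c3ccc(-c4nc5ccccc5[nH]4)cc3)cc2)c1` has not yet been measured. It differs from compound 3 as follows: 3-chlorophenyl in place of 4-hydroxyphenyl on an aromatic carbon. Going by the values given here, the one measured step, no change at the digits printed from compound 2 to compound 3 (within the scatter), swaps fluoro for hydroxy and shows no movement, but it does not involve the 3-chlorophenyl group. Among the compounds with values here, the closer guide is compound 1, the only measured compound with 3-chlorophenyl, at 3450 nM. Its core also carries a methyl group, and the data do not show what that methyl contributes. A clear shift towards stronger growth inhibition is therefore expected, though probably not the full distance to compound 1. The expected change is an 11-fold lower number from compound 3 to compound 4 (1.05 log units; beyond the scatter). Compound 4 is estimated at 9000 nM, with an expected range of 2500 nM to 60000 nM.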

Compound 4, concentration for 50% growth inhibition: 41200 nM
Compound 4: middle estimate off by 4.6-fold (0.66 log units), on the low side, and the stated range covers the measured number.
By their numbers in this assay, from the lowest: compound 1; then compound 4; then compounds 2 and 3 (each within the scatter of the next).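

In this assay, 3-chlorophenyl at this aromatic carbon on the shared core without the methyl gives only a modest gain, with a 2.4-fold lower number from compound 3 to compound 4 (0.39 log units; beyond the scatter) and a 2.4-fold lower number from compound 2 to compound 4 (0.39 log units; beyond the scatter). Unlike the swap of fluoro for hydroxy, this change moves the number beyond the scatter, but most of the distance to compound 1 lies elsewhere: the single change of methyl to hydrogen gives a 12-fold higher number from compound 1 to compound 4 (1.08 log units; beyond the scatter), a large step. Nothing shown here explains either size of step.

Going by these compounds, it remains open whether the same methyl would lower the number as much with 4-fluorophenyl or 4-hydroxyphenyl in place of 3-chlorophenyl. On these data alone, how 4-chlorophenyl, or a phenyl ring carrying an amine or a carboxylic acid, would read at this carbon also remains open.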